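A Para-Methyl Swap on a Weak Cytotoxic Scaffold

The source may hold more compounds than are shown below. What is called first, only, known or untested is meant among the compounds shown, and "the series" means these compounds.

Compound 1 `CNC(=O)c1cc(Oc2ccc(NC(=O)c3nccc(-c4cccc(Cl)c4)n3)cc2)ccn1` was tested in a functional assay on MCF7 cells (Homo sapiens) for cytotoxicity, read by MTT assay, with a stated time of 72 h; a lower number here means a stronger inhibitor, a higher number a weaker inhibitor. In this assay compound 1 gives > 100000 nM, which is a limit of the assay and not a number. Compound 1 therefore stands at the limit of > 100000 nM in this assay, at which 1 of the 2 values shown sits, the weaker end of what has been measured. Compound 2 `CCc1ccc(-c2cc(C(=O)Nc3ccc(Oc4ccnc(C(=O)NC)c4)c(F)c3)ncn2)cc1`, built on a different core, gives 7630 nM in this assay, well inside the measurable range. Compound 3 `CNC(=O)c1cc(Oc2ccc(NC(=O)c3nccc(-c4ccc(C)cc4)n3)cc2)ccn1` has not yet been measured. It differs from compound 1 in one place: 4-methylphenyl in place of 3-chlorophenyl on an aromatic carbon. Going by the values given here, no step between two measured compounds is recorded, so the size of this change can only be expected, not read off. Compound 2 shows that a compound of this general type can reach 7630 nM, but its core differs from the shared core of compound 1 and compound 3 in more than one place, so it gives only a loose anchor. The expected step of an at least 2.0-fold lower number from compound 1 to compound 3 (0.30 log units; that floor lies within the scatter) is a modest gain, with a considerable chance that compound 3 also reaches only the limit. The estimate for compound 3 is 50000 nM, ranging from 10000 nM to 150000 nM.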

Compound 3, half-maximal inhibitory concentration: 44300 nM
Compound 3: the middle estimate sits 1.1-fold (0.05 log units) above what was measured, and the stated range covers the measured number.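

With 4-methylphenyl in place of 3-chlorophenyl on this aromatic carbon, the shared core gives a value inside the measurable range of this assay, and the change yields an at least 2.2-fold lower number from compound 1 to compound 3 (0.35 log units; beyond the scatter). Going by these compounds alone, this is the first reading on this core, and it shows that the group on this carbon alters the result even though the two groups have the same ring, no hydrogen-bond donors or acceptors and no net charge. The true size of the step remains unknown, and only its floor can be read, because the value of compound 1 is a limit of the assay and not a number: the limit of > 100000 nM in this assay, at which 1 of the 3 values shown sits.

The change replaces chlorine with methyl and also alters the name's ring position from 3 to 4, so the compounds shown cannot tell which of these two differences accounts for the step. They also leave open how this position would respond to an amine or a carboxylic acid on the phenyl ring, or to a longer chain in place of the methyl group.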